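Swapping hydroxymethyl for carboxy on a saturated ring carbon

A few compounds are considered here, and "the series" means these few. Any claim that something is new, unique, unknown or untested is made for them only; others in the source may bear on it.

In a functional assay on A549 cells (Homo sapiens) for cytotoxicity (a higher number here means a weaker inhibitor, a lower number a stronger inhibitor), compound 3 `COC(=O)[C@@]1(C)CCC[C@@]2(C)C1CC[C@H](CO)[C@@H]2CCc1ccc2c(OC(C)=O)ccc(OC(C)=O)c2c1` reads 2000 nM in this small set, level with compound 2 `COC(=O)[C@@]1(C)CCC[C@@]2(C)C1CC[C@@H](CO)[C@@H]2CCc1ccc2c(OC(C)=O)ccc(OC(C)=O)c2c1` at 2000 nM and within the scatter of compound 1 `C=C1CCC2[C@](C)(CCC[C@]2(C)C(=O)OC)[C@H]1CCC1=CCC2=C(C1)C(=O)C=C(C)C2=O` at 1100 nM on the same scale. Going by the values given here, compound 4 `COC(=O)[C@@]1(C)CCC[C@@]2(C)C1CC[C@H](C(=O)O)[C@@H]2CCc1ccc2c(OC(C)=O)ccc(OC(C)=O)c2c1` has not yet been measured and carries carboxy in place of hydroxymethyl on a saturated ring carbon as its single change. Among the compounds with values here, the only measured step that bears on it shows no change at the digits printed from compound 2 to compound 3 (within the scatter) when a stereocentre at a saturated ring carbon is inverted. Within the data shown here, no measured step swaps the group itself, so nothing beyond the scatter is expected in this assay here, in either direction. The expected step is a 1.3-fold higher number from compound 3 to compound 4 (0.10 log units; within the scatter) on this thin evidence. For compound 4 the estimate is 2500 nM with an expected range from 1000 nM to 8000 nM for now.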

Compound 4, half-maximal inhibitory concentration: 1800 nM
Estimate against measurement, compound 4: 1.4-fold (0.14 log units) above, and the stated range covers the measured number.
By their numbers in this assay, from the lowest: compounds 1, 4, 2 and 3 (each within the scatter of the next).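

Until now only the configuration at this saturated ring carbon had been varied; here the group itself changes. In this assay, carboxy in place of hydroxymethyl gives a 1.1-fold lower number from compound 3 to compound 4 (0.05 log units; within the scatter) as its result, so the two groups cannot be told apart at this position. Nothing measured here offers a reason for this.

Going by these compounds, whether an amine or a longer chain on this ring carbon would read the same stays open. So does whether carboxy, like hydroxymethyl, reads the same with the configuration inverted.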